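The source may hold more compounds than are shown below. What is called first, only, known or untested is meant among the compounds shown, and "the series" means these compounds.

Compound 1, `Oc1ccc(-c2cncc(-c3cc4ccc(O)cc4[nH]3)n2)cc1`: 20000 nM
Compound 2, `CS(=O)(=O)c1ccc(-c2cncc(-c3cc4ccc(O)cc4[nH]3)n2)cc1`: 25000 nM
Compound 3, `Oc1ccc(-c2cncc(-c3cc4cc(O)ccc4[nH]3)n2)cc1`: 15000 nM

The three measured compounds were tested in an ADME assay on cells (Fibroblast, Homo sapiens) for cytotoxicity, with a stated time of 48 h; on this read-out higher numbers stand for weaker inhibition and lower numbers for stronger inhibition. In this assay compound 1 gives 20000 nM, compound 2 gives 25000 nM and compound 3 gives 15000 nM.

Compounds 1 and 2 differ in one place, (methylsulfonyl in place of hydroxy on an aromatic carbon). This change gives a 1.3-fold higher number from compound 1 to compound 2 (0.10 log units; within the scatter).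

Compound 3 shares its atoms with compound 1, but they are joined differently; the difference between the two cores is not broken down here. The values of compound 3 and compound 1 lie within the scatter of each other, as do those of compound 3 and compound 2.

Compound 4, `CS(=O)(=O)c1ccc(-c2cncc(-c3cc4cc(O)ccc4[nH]3)n2)cc1`, has not yet been measured in this assay. It stands to compound 3 as compound 2 stands to compound 1: methylsulfonyl in place of hydroxy on an aromatic carbon. The place of the change is described in the same words for both pairs, so it is the same kind of change on a different core.

For the measured compounds named here, since the one measured example of this change, from compound 1 to compound 2, stayed within the scatter, compound 4 is expected to give a number close to that of compound 3, with a step of a 1.3-fold higher number from compound 3 to compound 4 (0.10 log units; within the scatter). On that basis the estimate for compound 4 in this assay is 19000 nM, expected to fall between 9000 nM and 40000 nM.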

Compound 4, half-maximal inhibitory concentration: 25000 nM
For compound 4 the middle estimate is 1.3-fold (0.12 log units) below the measured one; the measured number falls inside the stated range.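

In this assay, methylsulfonyl in place of hydroxy on an aromatic carbon gives a 1.7-fold higher number from compound 3 to compound 4 (0.22 log units; within the scatter), so on this second core, as on the first, the step stays within the usual spread of repeated measurements. Set side by side, the two steps cannot be told apart, and the change carries over between these two cores without a detectable shift: the same change on two cores in this assay, a 1.3-fold higher number (0.10 log units; within the scatter) from compound 1 to compound 2 and a 1.7-fold higher number (0.22 log units; within the scatter) from compound 3 to compound 4, 1.3-fold (0.12 log units) apart, within the scatter of two such steps. For the compounds shown here, this shows only that the swap behaves alike on two cores made of the same atoms joined differently; since neither step rises above the scatter, it does not show that the change has any real effect here, and it says nothing about cores of another kind.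

The compounds shown leave open whether other groups in the same place, para to a large group, such as an amine, a carboxylic acid or a longer chain, would also stay within the scatter of hydroxy in this assay. Also open, as far as these compounds go, is what would happen if the other hydroxy, which all four compounds carry on the core, were replaced by one of these groups or by methylsulfonyl.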